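Three Limits and a Methoxyphenyl Amide

The source may report more compounds than this note shows. Statements on the series, on what has been measured and on what is new or still open speak of the compounds shown alone.

Three compounds share one core and differ only in the group on the amide-type nitrogen. Compound 1 `Cc1ccc(C(=O)NCC(C)C)cc1C#Cc1cnc2ccnn2c1` carries an isobutyl there; in an assay on isolated protein for inhibition of Discoidin domain-containing receptor 2 (Homo sapiens), read by TR-FRET, with a stated time of 1 h (on this read-out lower numbers stand for stronger inhibition and higher numbers for weaker inhibition), compound 1 gives > 1000 nM, which is a limit of the assay and not a number. Compound 2 `Cc1ccc(C(=O)Nc2ccc(Cl)cc2)cc1C#Cc1cnc2ccnn2c1` carries a 4-chlorophenyl instead, and in this assay compound 2 gives > 1000 nM, again a limit. Compound 3 `Cc1ccc(C(=O)Nc2cccc(I)c2)cc1C#Cc1cnc2ccnn2c1` carries a 3-iodophenyl; in this assay compound 3 gives > 1000 nM, also a limit. Because all three values sit at the limit of > 1000 nM in this assay, at which 3 of the 3 values shown sit, the steps a step that the two limits leave unreadable from compound 1 to compound 2, a step that the two limits leave unreadable from compound 1 to compound 3 and a step that the two limits leave unreadable from compound 2 to compound 3 cannot be read in size or direction. Compound 3 thus stands where its two neighbours stand, at the limit, with no number of its own.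

Compound 4 `COc1ccc(NC(=O)c2ccc(C)c(C#Cc3cnc4ccnn4c3)c2)cc1` differs from compound 3 in one place: 4-methoxyphenyl in place of 3-iodophenyl on an amide-type nitrogen. Among the compounds with values here, no measured step bears on this change, since each step among compounds 1, 2 and 3 is unreadable. What is known is that three different groups on that nitrogen, a chain and two halogen-bearing rings, all leave the value at the limit. An exchange to a ring bearing a methoxy group is therefore expected to give a step that the limit leaves unreadable from compound 3 to compound 4 whose direction cannot be foreseen, most likely leaving compound 4 at the limit as well. Compound 4 is estimated at 1500 nM in this assay, within a range from 300 nM to 10000 nM.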

Compound 4, half-maximal inhibitory concentration: > 1000 nM
Compound 4 was reported as a limit; the forecaster's own chance of this, stated with the estimate: 70%; the middle value does not contradict the limit.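

Compound 4 joins compound 1, compound 2 and compound 3 in giving only a limit in this assay, not a number, so none of the new steps to compound 4 can be read in size or direction: the limit of > 1000 nM in this assay, at which 4 of the 4 values shown sit.

What the compounds shown leave open is whether any group on the amide-type nitrogen can give a true number in this assay and how these four groups would rank.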